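The source may report more compounds than this note shows. Statements on the series, on what has been measured and on what is new or still open speak of the compounds shown alone.

Measured so far in an assay on HEK293 cells for displacement of a labelled ligand from metabotropic glutamate receptor 5 (Homo sapiens), with a stated time of 2 h; on this read-out lower numbers stand for stronger inhibition and higher numbers for weaker inhibition:
compound 1 `O=C1c2ccc(C#Cc3ccccc3)nc2CCN1C1CCCC1` gives 890 nM
compound 2 `O=C1c2ccc(C#Cc3cccc(Cl)c3)nc2CCN1C1CCCC1` gives 5230 nM
compound 3 `COc1cccc(C#Cc2ccc3c(n2)CCN(C2CCCC2)C3=O)c1` gives > 32000 nM

For compound 3 the value is a limit of the assay, not a number (the limit of > 32000 nM in this assay, at which 1 of the 3 values shown sits). Compound 3 thus stands at the weak end of the three compounds shown: the step of an at least 35-fold higher number from compound 1 to compound 3 (1.55 log units; beyond the scatter) is large, and the step of an at least 6.1-fold higher number from compound 2 to compound 3 (0.78 log units; beyond the scatter) is at least modest, both set by that limit. The step of a 5.9-fold higher number from compound 1 to compound 2 (0.77 log units; beyond the scatter) is modest.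

Compound 4 `O=C1c2ccc(C#Cc3cccs3)nc2CCN1C1CCCC1` is not yet measured. It differs from compound 3 by thiophen-2-yl in place of 3-methoxyphenyl on a triple-bonded carbon. The change removes the methoxy group and replaces the whole 3-methoxyphenyl by a five-membered aromatic ring with one hetero atom. For the measured compounds named here, no measured step covers a thiophen-2-yl, so the closest guide is compound 1, whose phenyl carries hydrogen where compound 3 carries methoxy. A reversal of the large loss is expected, back toward compound 1, with some allowance for the ring change. In this assay compound 4 is expected at 1500 nM (range 400 nM to 6000 nM), which would be a step of an at least 21-fold lower number from compound 3 to compound 4 (1.32 log units; beyond the scatter).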

Compound 4, inhibition constant: 2840 nM
The estimate for compound 4 lay 1.9-fold (0.28 log units) below the measured number, and the stated range covers the measured number.
By their numbers in this assay, from the lowest: compound 1; then compounds 4 and 2 (each within the scatter of the next). At a limit, above all of these: compound 3.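

Thiophen-2-yl shows that the ring on the triple-bonded carbon can be exchanged as a whole, not only substituted, and a five-membered aromatic ring with one hetero atom still gives a measurable number in this assay, with a 3.2-fold higher number from compound 1 to compound 4 (0.50 log units; beyond the scatter). Thiophen-2-yl and 3-chlorophenyl cannot be told apart in this assay, with a 1.8-fold lower number from compound 2 to compound 4 (0.27 log units; within the scatter). Against 3-methoxyphenyl the change gives an at least 11-fold lower number from compound 3 to compound 4 (1.05 log units; beyond the scatter), which is a bound and not a measured size, as compound 3 stands at a limit of the assay: the limit of > 32000 nM in this assay, at which 1 of the 4 values shown sits.

As far as these compounds go, it remains open whether a ring carrying nitrogen, such as pyridin-2-yl or thiazol-2-yl, would match the value of compound 1. Also open, from the compounds shown here alone, is how a methyl or a fluoro on the thiophene ring would act.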